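The source may hold more compounds than are shown below. What is called first, only, known or untested is meant among the compounds shown, and "the series" means these compounds.

Compound 1 `O=C(O)COc1ccc(Cl)cc1C#Cc1ccccc1` gives 108 nM in an assay on CHO cells for displacement of a labelled ligand from prostaglandin D2 receptor 2 (Homo sapiens), read by scintillation counting; on this read-out higher numbers stand for weaker inhibition and lower numbers for stronger inhibition. Compound 2 `CS(=O)(=O)c1cccc(C#Cc2cc(Cl)ccc2OCC(=O)O)c1` gives 15 nM. Compound 3 `CN(C)S(=O)(=O)c1cccc(C#Cc2cc(Cl)ccc2OCC(=O)O)c1` gives 14 nM.

Among these three numbers compound 2 stands second highest. Its nearest neighbour is compound 3, the step of a 1.1-fold lower number from compound 2 to compound 3 (0.03 log units; within the scatter) lying within the scatter, so the two cannot be ordered; the furthest is compound 1, from which compound 2 is reached by a 7.2-fold lower number from compound 1 to compound 2 (0.86 log units; beyond the scatter).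

Compound 4 `CC(C)c1ccc(S(C)(=O)=O)cc1C#Cc1cc(Cl)ccc1OCC(=O)O` differs from compound 2 in one place: isopropyl in place of hydrogen on an aromatic carbon. Within the data shown here, no measured step touches this position. Among the measured compounds shown here, the steps of a 7.2-fold lower number from compound 1 to compound 2 (0.86 log units; beyond the scatter) and a 7.7-fold lower number from compound 1 to compound 3 (0.89 log units; beyond the scatter) each introduced a sulfonyl-bearing group where hydrogen had been, and a 1.1-fold lower number from compound 2 to compound 3 (0.03 log units; within the scatter) exchanged the group on the sulfonyl sulfur; an isopropyl group ortho to a large group and para to a methylsulfonyl group has no counterpart among them. The expected step in this assay therefore has no established direction and is most likely not beyond the scatter, the estimated step being no change at the digits printed from compound 2 to compound 4 (within the scatter). Compound 4 is estimated at 15 nM, with a range from 5 nM to 45 nM.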

Compound 4, inhibition constant: 4.6 nM
Compound 4: the middle estimate sits 3.3-fold (0.51 log units) above what was measured; the measured number lies below the stated range.
By their numbers in this assay, from the lowest: compound 4; then compounds 3 and 2 (each within the scatter of the next); then compound 1.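

In this assay the aromatic carbon ortho to a large group and para to a methylsulfonyl group, which carries hydrogen in compound 2, accepts an isopropyl group with a modest gain, a 3.3-fold lower number from compound 2 to compound 4 (0.51 log units; beyond the scatter), beyond the scatter. Among these compounds, the earlier steps changed only the sulfonyl-bearing group or the group on the sulfonyl sulfur, so this is the first sign that a carbon substituent at a second place on that ring moves the number, and here it moves it down. Nothing available explains this step. The compounds shown leave open whether a methyl group, a cyclopropyl ring or an amine at this carbon would lower the number as well, or by as much. They also leave open whether isopropyl would give a similar step alongside dimethylsulfamoyl, the group of compound 3.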